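The source may report more compounds than this note shows. Statements on the series, on what has been measured and on what is new or still open speak of the compounds shown alone.

Working notes on the series.

Three compounds of the shared core have numbers in an ADME assay for permeability, using PAMPA, with a stated time of 30 min, at pH 7.4; a lower number here means that the compound crosses the layer more slowly, a higher number that the compound crosses the layer faster. Compound 1 `COc1ccc(Oc2ccc3c(NCCCNCc4cc(F)ccc4OC)ccnc3c2)cc1` gives 317 10^-6 cm/s in this assay. Compound 2 `COc1cccc(CNCCCNc2ccnc3cc(-c4ccc(C(C)(C)C)cc4)ccc23)c1O` gives 237 10^-6 cm/s. Compound 3 `COc1cccc(CNCCCNc2ccnc3cc(Cc4ccc(F)cc4)ccc23)c1O` gives 23 10^-6 cm/s, the lowest of the three; the gap to compound 2 is beyond the scatter, as is the wider gap to compound 1.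

Within the data shown here, the only measured step that changes one place is a 10-fold lower number from compound 2 to compound 3 (1.01 log units; beyond the scatter), which replaces 4-(tert-butyl)phenyl with 4-fluorobenzyl on the aromatic carbon of the core.

Compound 4 `COc1ccc(Oc2ccc3c(NCCCNCc4cccc(OC)c4O)ccnc3c2)cc1` is not yet measured in this assay. It differs from compound 3 in one place: 4-methoxyphenoxy in place of 4-fluorobenzyl on an aromatic carbon. This is the same aromatic carbon that the step from compound 2 to compound 3 touched, so that step bears on it directly; it was large, and compound 4 moves away from 4-fluorobenzyl again. Compound 1 carries 4-methoxyphenoxy on that same carbon and gives 317 10^-6 cm/s, with a different benzyl group on the chain. A large upward step is therefore expected in this assay, an 8.7-fold higher number from compound 3 to compound 4 (0.94 log units; beyond the scatter), beyond the scatter. Compound 4 is estimated at 200 10^-6 cm/s, with a range from 70 10^-6 cm/s to 400 10^-6 cm/s.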

Compound 4, apparent permeability: 317 10^-6 cm/s
Compound 4: the middle estimate sits 1.6-fold (0.20 log units) below what was measured; measured number inside the range.
By their numbers in this assay, from the lowest: compound 3; then compounds 2, 1 and 4 (each within the scatter of the next).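

At the aromatic carbon of the shared core, 4-fluorobenzyl now stands alone at the low end of this assay: with the 2-hydroxy-3-methoxyphenyl group held on the chain, the swap to 4-methoxyphenoxy gives a 14-fold higher number from compound 3 to compound 4 (1.14 log units; beyond the scatter), while the swap from 4-(tert-butyl)phenyl gives a 1.3-fold higher number from compound 2 to compound 4 (0.13 log units; within the scatter), so these two larger-numbered groups cannot be told apart here. The chain change, at 4-methoxyphenoxy, gives no change at the digits printed from compound 1 to compound 4 (within the scatter), so the 5-fluoro-2-methoxyphenyl and 2-hydroxy-3-methoxyphenyl groups are not separated in this read-out, and the number of compound 1 can be read alongside those of its chain-matched neighbours. Nothing on hand explains why the number moves at this carbon.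

On these data alone, the low number rests on compound 3 alone, so it remains open whether it goes with the fluorine of 4-fluorobenzyl or with its carbon link to the core, a question that 4-fluorophenoxy on the same carbon would address. Also open, as far as these compounds go, is whether the high numbers would hold with a morpholine or a carboxylic acid at this carbon, or with a longer chain between the two nitrogens.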